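The compounds below may be only part of what the source reports. "The series", "measured", "known", "first", "only" and "open" are said of these compounds alone.

Compound 1 `Cc1nc(C#Cc2cc(F)cc(Br)c2)cs1` and compound 2 `Cc1nc(C#Cc2cc(Br)cc(Br)c2)cs1` share one core, while compound 3 `O=[N+]([O-])c1cc(Br)cc(C#Cc2ccccn2)c1` is built on another; the difference between the two cores is not broken down here. In a functional assay on HEK293 cells for antagonist activity at metabotropic glutamate receptor 5 (Rattus norvegicus), read by calcium flux (a lower number here means a stronger inhibitor, a higher number a weaker inhibitor), compound 2 gives 1.45 nM, compound 1 gives 1.11 nM, and compound 3 gives 0.39 nM, the lowest of the three. The change from compound 2 to compound 1 is fluoro in place of bromo on an aromatic carbon and produced a 1.3-fold lower number from compound 2 to compound 1 (0.12 log units; within the scatter). Compound 4 `O=[N+]([O-])c1cc(F)cc(C#Cc2ccccn2)c1` carries the same kind of change on the core of compound 3, (fluoro in place of bromo on an aromatic carbon), though here the place is meta to a nitro group rather than meta to a bromo group. For compound 4 in this assay a step of about a 1.3-fold lower number from compound 3 to compound 4 (0.11 log units; within the scatter) is expected. That expectation rests on the earlier step, a 1.3-fold lower number from compound 2 to compound 1 (0.12 log units; within the scatter), which stayed within the scatter. Compound 4 is therefore estimated at 0.3 nM, between 0.12 nM and 0.8 nM.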

Compound 4, half-maximal inhibitory concentration: 0.66 nM
Estimate against measurement, compound 4: 2.2-fold (0.34 log units) below; the range from low to high includes it.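

In this assay, fluoro in place of bromo on the core of compound 3 gave a 1.7-fold higher number from compound 3 to compound 4 (0.23 log units; within the scatter). Set beside the same change on the other core, this step does not differ from the earlier one by more than the scatter allows: the same change on two cores in this assay, a 1.3-fold lower number (0.12 log units; within the scatter) from compound 2 to compound 1 and a 1.7-fold higher number (0.23 log units; within the scatter) from compound 3 to compound 4, 2.2-fold (0.34 log units) apart, within the scatter of two such steps So across these two pairs, the exchange of bromo for fluoro carried from one core to the other without a step beyond the scatter, but with both steps inside the scatter, no direction can be read, and two pairs do not establish a rule for other cores.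

The compounds shown leave open how chloro or methyl would compare in the place of the halogen. As far as these compounds go, it also remains open whether fluoro and bromo would still stand as close on a core carrying an amine or a carboxylic acid where compound 3 has its nitro group.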